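The source may report more compounds than this note shows. Statements on the series, on what has been measured and on what is new or still open speak of the compounds shown alone.

Compound 1 `COc1ccc(C(=O)/C=C\Nc2ccc(-c3nc4cc(OC)c(OC)c(OC)c4s3)cc2C)cc1O`: 15400 nM
Compound 2 `COc1cc(OC)c2sc(-c3ccc(N/C=C\C(=O)c4ccc(OC)c(O)c4)cc3)nc2c1`: 10600 nM

Both compounds were tested in a functional assay on A549 cells (Homo sapiens) for antiproliferative activity, read by sulforhodamine B assay, with a stated time of 48 h (a lower number here means a stronger inhibitor, a higher number a weaker inhibitor), where compound 2 gives 10600 nM and compound 1 gives 15400 nM. These two numbers lie within the usual scatter of each other, so the measurements do not separate compound 2 from compound 1. Both sit in the same range of the scale.

Compound 3 `COc1ccc(C(=O)/C=C\Nc2ccc(-c3nc4cc(OC)c(OC)c(OC)c4s3)cc2)cc1O` has not yet been measured. It differs from compound 2 at a single place: methoxy in place of hydrogen on an aromatic carbon. In other words, a methoxy stands in place of a hydrogen on an aromatic carbon. Among the compounds with values here, no pair of measured compounds shows this change on its own, so the data give no direct size for it. Within the data shown here, with only two values to go on, a large shift has no support, and the safest expectation is little movement, with a slight lean towards a lower number. The expected 1.2-fold lower number from compound 2 to compound 3 (0.10 log units; within the scatter) is therefore small and not beyond the scatter. For compound 3 the estimated value is 8500 nM, with an expected range of 2500 nM to 22000 nM.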

Compound 3, half-maximal inhibitory concentration: 23000 nM
Compound 3: the middle estimate sits 2.7-fold (0.43 log units) below what was measured; measured number above the stated range.
By their numbers in this assay, from the lowest: compounds 2, 1 and 3 (each within the scatter of the next, the first and the last beyond it).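

In this assay, placing a methoxy on the aromatic carbon that is ortho to two methoxy groups gives a 2.2-fold higher number from compound 2 to compound 3 (0.34 log units; beyond the scatter), so this position of the fused system does respond to substitution, and here the added group goes with a modestly weaker compound. The second change, hydrogen in place of methyl on an aromatic carbon of the other ring system, gives a 1.5-fold higher number from compound 1 to compound 3 (0.17 log units; within the scatter), and this lies within the scatter, so the assay does not separate these two compounds. The data offer no measurement that explains why the methoxy step has this size.

From the compounds shown here alone, the methoxy effect rests on a single pair of compounds, so it remains open whether a weaker compound follows from any group at this position or from methoxy alone. A fluorine, a hydroxyl, an amine or a longer chain such as ethoxy at the same carbon would show whether the trend depends on the size or the kind of group placed there.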